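Bromo in place of chloro: a single swap

The source may hold more compounds than are shown below. What is called first, only, known or untested is meant among the compounds shown, and "the series" means these compounds.

Measured so far in a functional assay on A549 cells (Homo sapiens) for cytotoxicity, read by MTT assay, with a stated time of 72 h; on this read-out higher numbers stand for weaker inhibition and lower numbers for stronger inhibition:
Compound 1 `CSc1nc(Br)c(C(=O)c2ccccc2)s1`: 97000 nM
Compound 2 `O=C(c1ccccc1)c1sc(N2CCCC2)nc1Cl`: 50000 nM

Among the measured compounds shown here, only these two compounds have numbers so far. Compound 2 stands within the usual scatter of compound 1, so repeated measurements could not reliably tell the two apart.

Compound 3 `O=C(c1ccccc1)c1sc(N2CCCC2)nc1Br` matches compound 2 except in one place, with bromo in place of chloro on an aromatic carbon. That carbon sits next to the ring nitrogen. For the measured compounds named here, no measured pair shows this swap on its own, so the data offer no direct guide to its size.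

Starting from compound 2 at 50000 nM, no step beyond the scatter is expected in this assay, and neither direction is favoured. The estimated step is no change at the digits printed from compound 2 to compound 3 (within the scatter). For compound 3 the estimated value is 50000 nM, with an expected range from 22000 nM to 110000 nM.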

Compound 3, half-maximal inhibitory concentration: 97000 nM
For compound 3 the middle estimate is 1.9-fold (0.29 log units) below the measured one; the range from low to high includes it.
By their numbers in this assay, from the lowest: compounds 2, 1 and 3 (each within the scatter of the next).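

In this assay, bromo in place of chloro on the aromatic carbon next to the ring nitrogen gives a 1.9-fold higher number from compound 2 to compound 3 (0.29 log units; within the scatter), so repeated measurements could not reliably tell these two halogens apart at this position. With bromo held constant, pyrrolidin-1-yl in place of methylsulfanyl on an aromatic carbon gives no change at the digits printed from compound 1 to compound 3 (within the scatter), so this second swap also stays within the scatter of the assay. No further data accompany these numbers to explain either step.

Since both steps stay within the scatter, the compounds shown do not reveal whether either position affects the read-out at all. On these data alone, it remains open whether an amine or a nitrile on the carbon now bearing the halogen, or a longer chain in place of pyrrolidin-1-yl, would give a step beyond the scatter.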